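A few compounds are considered here, and "the series" means these few. Any claim that something is new, unique, unknown or untested is made for them only; others in the source may bear on it.

Measured compounds:
- compound 1, `CCCc1c(OC)nc2nc(C(=O)c3ccccc3)cn2c1CC`, 10 mg/kg in a functional assay on the whole organism with Rattus norvegicus as the target; on this read-out lower numbers stand for an effect already at smaller amounts and higher numbers for an effect only at larger amounts of compound
- compound 2, `C=CCc1c(OC)nc2nc(C(=O)c3ccccc3)cn2c1CC`, 10 mg/kg in this assay
- compound 3, `C=CCc1c(OC)nc2nc(C(=O)c3ccccc3)cn2c1C`, 5 mg/kg in this assay

Compound 2 stands level with compound 1 at the digits shown, and the two together give the highest numbers of the three; compound 3 lies nearest below it, the step of a 2.0-fold lower number from compound 2 to compound 3 (0.30 log units; within the scatter) being within the scatter. Among the compounds with values here, the only other step available, no change at the digits printed from compound 1 to compound 2 (within the scatter), is likewise within the scatter.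

Compound 4, `CCc1cc(OC)nc2nc(C(=O)c3ccccc3)cn12`, has not yet been tested in this assay. It differs from compound 2 as follows: hydrogen in place of allyl on an aromatic carbon. Neither measured step bears directly on this change: one swaps vinyl for ethyl on a saturated chain carbon, the other swaps hydrogen for methyl on a saturated chain carbon, and both stay within the scatter. Within the data shown here, removing the whole allyl group from the aromatic carbon goes further than either, so no measured step predicts its size or direction. On the small steps seen so far, compound 4 is expected to show a step of no change at the digits printed from compound 2 to compound 4 (within the scatter), that is, nothing beyond the scatter, and its estimated value is 10 mg/kg with a range from 4 mg/kg to 30 mg/kg.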

Compound 4, minimum effective dose: 2 mg/kg
The estimate for compound 4 lay 5.0-fold (0.70 log units) above the measured number; measured number below the stated range.
By their numbers in this assay, from the lowest: compound 4; then compounds 3, 1 and 2 (each within the scatter of the next).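

In this assay, the position on the aromatic carbon ortho to a methoxy group and ortho to an ethyl group gives steps beyond the scatter: a 5.0-fold lower number from compound 2 to compound 4 (0.70 log units; beyond the scatter) when hydrogen replaces allyl, and a 5.0-fold lower number from compound 1 to compound 4 (0.70 log units; beyond the scatter) when hydrogen replaces propyl. The steps among compounds 1, 2 and 3 changed only the chains and stayed within the scatter, whereas these show that the number falls when the chain at this position is removed altogether, whether that chain is allyl or propyl. No measurement shown bears on why this happens.

Going by these compounds, it remains open whether a methyl group or an amine at this position would keep the lower number. On these data alone, it is also open whether the same step would appear with a methyl group in place of the ethyl group that compound 4 carries.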